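Carbamoyl variation on the benzyl arm: isopropyl to phenyl

A few compounds are considered here, and "the series" means these few. Any claim that something is new, unique, unknown or untested is made for them only; others in the source may bear on it.

The three measured compounds share one core and differ only in the substituent on the benzyl arm. Compound 1 `Cc1nn(Cc2ccccc2)c(C)c1NC(=O)c1ccc(COc2ccccc2)cc1` carries hydrogen there; in a functional assay on MIA PaCa-2 cells (Homo sapiens) for antiproliferative activity, read by MTT assay, with a stated time of 72 h (a higher number here means that more compound is needed for the effect, a lower number that less compound is needed), compound 1 gives 10000 nM. Compound 2 `Cc1nn(Cc2cccc(C(=O)N(C)C)c2)c(C)c1NC(=O)c1ccc(COc2ccccc2)cc1` carries dimethylcarbamoyl, and in this assay compound 2 gives 6400 nM. Compound 3 `Cc1nn(Cc2cccc(C(=O)NC(C)C)c2)c(C)c1NC(=O)c1ccc(COc2ccccc2)cc1` carries isopropylcarbamoyl; in this assay compound 3 gives 8900 nM, which is the second highest of the three numbers but within the scatter of both others. The steps are a 1.6-fold lower number from compound 1 to compound 2 (0.19 log units; within the scatter), a 1.1-fold lower number from compound 1 to compound 3 (0.05 log units; within the scatter) and a 1.4-fold higher number from compound 2 to compound 3 (0.14 log units; within the scatter): neither adding a carbamoyl group nor exchanging the amine on its carbonyl carbon moved the read-out beyond the scatter.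

Compound 4 `Cc1nn(Cc2cccc(C(=O)Nc3ccccc3)c2)c(C)c1NC(=O)c1ccc(COc2ccccc2)cc1` takes the amine exchange one step further: phenyl in place of isopropyl on an amide-type nitrogen. The step bearing most directly on it is the earlier amine exchange, a 1.4-fold higher number from compound 2 to compound 3 (0.14 log units; within the scatter), which stayed within the scatter; the two additions starting from compound 1 were also within the scatter. For the measured compounds named here, with no step in the set beyond the scatter, no movement beyond the scatter is expected here either, in either direction. For compound 4 in this assay the estimate is 8000 nM, with a range from 3000 nM to 25000 nM. The expected step is accordingly a 1.1-fold lower number from compound 3 to compound 4 (0.05 log units; within the scatter), flat within the scatter.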

Compound 4, half-maximal effective concentration: 6400 nM
Compound 4: the middle estimate sits 1.3-fold (0.10 log units) above what was measured, within the range that was stated.
By their numbers in this assay, from the lowest: compounds 2, 4, 3 and 1 (each within the scatter of the next).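

In this assay, the amide-type nitrogen now carries a six-membered aromatic ring of 6 heavy atoms in place of the 3 of isopropyl, and the step still lies within the scatter (a 1.4-fold lower number from compound 3 to compound 4 (0.14 log units; within the scatter)). For the compounds shown here, the same holds against the other two compounds, both for anilino in place of dimethylamino on the carbonyl carbon (no change at the digits printed from compound 2 to compound 4 (within the scatter)) and for phenylcarbamoyl in place of hydrogen on the aromatic carbon (a 1.6-fold lower number from compound 1 to compound 4 (0.19 log units; within the scatter)), so no step among the four compounds separates any one of them from the others, and an aromatic ring on this nitrogen adds no separation that the alkyl groups did not give. No measurement is available that bears on why the read-out stays flat across these changes.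

Still open, on these data alone, is whether a group of a different kind on this arm, such as a carboxylic acid, a basic amine or a longer chain ending in a morpholine on the amide nitrogen, would move the read-out beyond the scatter. Also open, as far as these compounds go, is whether a substituted phenyl in place of the plain phenyl of compound 4 would do so.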